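A few compounds are considered here, and "the series" means these few. Any claim that something is new, unique, unknown or untested is made for them only; others in the source may bear on it.

In a physicochemical assay for lipophilicity, using the shake flask method, in phosphate buffer, measured as octanol-water partition, with a stated time of 1 h, at pH 7.4 (on this read-out lower numbers stand for lower lipophilicity and higher numbers for higher lipophilicity), the series so far reads:

Compound 1 `CCNC(=O)Nc1cc(Cl)c(-c2cncc(C(=O)O)c2)cn1`: -1.1
Compound 2 `CCNC(=O)Nc1cc(Br)c(-c2cncc(C(=O)O)c2)cn1`: -1

Compound 2 cannot be told apart from compound 1 on these numbers. Among the measured compounds shown here, the only measured step, a number 0.10 log units higher from compound 1 to compound 2 (within the scatter), is bromo in place of chloro on an aromatic carbon, and it lies within the scatter.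

The next change leads to compound 3 `CCNC(=O)Nc1cc(-c2ccccc2)c(-c2cncc(C(=O)O)c2)cn1`, which is still unmeasured: phenyl in place of bromo on an aromatic carbon. In words, this is phenyl in place of bromo on an aromatic carbon, opposite the ring nitrogen and ortho to a group of 9 heavy atoms. The measured step bears on this only weakly. It exchanges one halogen for another, whereas here a six-membered aromatic ring of carbon only enters. For the measured compounds named here, no measured compound shows what such a ring does in this assay, so the expectation rests on the structural change more than on the data. A clear upward move in this assay, beyond the scatter, is expected, and the estimated move is a number 0.60 log units higher from compound 2 to compound 3 (beyond the scatter). For compound 3 the estimate is -0.4, with an expected range of -0.9 to 0.1.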

Compound 3, distribution coefficient: -0.31
Compound 3: middle estimate off by 0.09 log units, on the low side; measured number inside the range.
By their numbers in this assay, from the lowest: compounds 1 and 2 (each within the scatter of the next); then compound 3.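

In this assay, the position opposite the ring nitrogen proves responsive to what it carries: the step of a number 0.69 log units higher from compound 2 to compound 3 (beyond the scatter) and the step of a number 0.79 log units higher from compound 1 to compound 3 (beyond the scatter) both lie beyond the scatter, whereas the halogen exchange a number 0.10 log units higher from compound 1 to compound 2 (within the scatter) stayed within it. Either halogen can therefore give way to phenyl, with its 6 heavy atoms and one six-membered aromatic ring of carbon only, and the number rises by a similar modest step, so the earlier indifference of this position holds only for the exchange of one halogen for another. No accompanying measurement gives a reason for the rise.

Phenyl is the only non-halogen group shown at this position, so it remains open whether a saturated ring such as cyclohexyl, a small methyl group, a longer alkyl chain or an amine would shift the number in the same direction, or by a comparable step. Also open, from the compounds shown here alone, is whether a phenyl ring bearing a further group, such as methoxy or a second carboxylic acid, would keep or reverse this upward step.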